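Aryl exchange on the carbonyl carbon of compound 1

The source may hold more compounds than are shown below. What is called first, only, known or untested is meant among the compounds shown, and "the series" means these compounds.

Working notes on the series. Three compounds have been run in a functional assay on RXF 393 cells (Homo sapiens) for cytotoxicity, read by sulforhodamine B assay, with a stated time of 48 h, tested at 1 uM; on this read-out lower numbers stand for a stronger effect and higher numbers for a weaker effect at the one concentration tested. Compound 1 `COc1cc(-c2cc(/C=C/C(=O)c3ccc(Cl)c(Cl)c3)[nH]n2)cc(OC)c1OC` gives 81% in this assay. Compound 3 `COc1ccc(-c2cc(/C=C/C(=O)c3cc(OC)c(OC)c(OC)c3)[nH]n2)cc1OC` gives 80%, within the scatter of compound 1. Compound 2 `COc1ccc(-c2cc(/C=C/C(=O)c3ccc(N)cc3)[nH]n2)cc1OC` gives 94%, a number beyond the scatter and higher than that of compound 1. Compound 1 therefore stands second highest of the three numbers, nearest to compound 3 and furthest from compound 2.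

Compound 4 `COc1ccc(C(=O)/C=C/c2cc(-c3cc(OC)c(OC)c(OC)c3)n[nH]2)cc1OC` awaits measurement. It differs from compound 1 by 3,4-dimethoxyphenyl in place of 3,4-dichlorophenyl on a carbonyl carbon. For the measured compounds named here, no step between measured compounds carries this change. Compound 3, also varied at the carbonyl carbon, gives 80%, close to compound 1. The step of a number 1 percentage points higher from compound 1 to compound 4 (within the scatter) is expected to stay within the scatter. Compound 4 is estimated at 82%, with a range from 70% to 95%.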

Compound 4, a percentage reported as activity, at one concentration (the size of the read-out at that concentration, not a potency): 72%
Compound 4: the middle estimate sits 10 percentage points above what was measured; the range from low to high includes it.
By their numbers in this assay, from the lowest: compounds 4, 3 and 1 (each within the scatter of the next); then compound 2.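

In this assay, the series gains its first step that changes one place only, at the carbonyl carbon: a number 9 percentage points lower from compound 1 to compound 4 (within the scatter). Exchanging 3,4-dichlorophenyl for 3,4-dimethoxyphenyl at this position therefore gives no difference that can be told from the scatter, although the entering group carries hydrogen-bond acceptors and the leaving group none. Nothing measured on these compounds accounts for the step.

On these data alone, whether a carboxylic acid or a longer alkyl chain on this carbonyl carbon, in place of the aromatic ring, would give a step beyond the scatter remains open.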